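A few compounds are considered here, and "the series" means these few. Any claim that something is new, unique, unknown or untested is made for them only; others in the source may bear on it.

Series notes, read-out a functional assay on the whole organism (strain BALB/c) for inhibition, with Mus musculus as the target, read by paw edema, with a stated time of 4 h, at a dose of 50 mg/kg by the oral route; on this read-out higher numbers stand for more inhibition at the one dose given (going by the name of the read-out) and lower numbers for less inhibition.

Compound 1 `CNc1nnc(-c2cc(-c3ccc(F)cc3F)ccc2O)o1` gives 41.4% in this assay. For the measured compounds named here, compound 2 `Oc1ccc(-c2ccc(F)cc2F)cc1-c1nnc(NC2CCCCC2)o1` gives 23.8% in this assay, the lowest of the two numbers so far; the one measured step, a number 17.6 percentage points lower from compound 1 to compound 2 (beyond the scatter), is the change of cyclohexyl in place of methyl on a nitrogen on an aromatic ring.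

Compound 3 `Cc1ccc(Nc2nnc(-c3cc(-c4ccc(F)cc4F)ccc3O)o2)cc1` is not yet measured. Its difference from compound 2 is 4-methylphenyl in place of cyclohexyl on a nitrogen on an aromatic ring. Going by the values given here, no measured step covers a six-membered aromatic ring at this nitrogen; the only step at this position, a number 17.6 percentage points lower from compound 1 to compound 2 (beyond the scatter), went from a small group to a larger saturated ring and lowered the number. Whether a 4-methylphenyl group behaves like cyclohexyl or like methyl cannot be read from two compounds, so the expected step of a number 6.2 percentage points higher from compound 2 to compound 3 (within the scatter) is small, within the scatter, with a wide range. For compound 3 the estimate in this assay is 30%, between 12% and 50%.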

Compound 3, a percentage reported as inhibition, in the whole organism at one dose (the size of the read-out at that dose, not a potency): 33.8%
For compound 3 the middle estimate is 3.8 percentage points below the measured one; the measured number falls inside the stated range.
By their numbers in this assay, from the lowest: compounds 2, 3 and 1 (each within the scatter of the next, the first and the last beyond it).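

In this assay the nitrogen now carries a third group, and 4-methylphenyl does not separate from either of the other two: a number 10 percentage points higher from compound 2 to compound 3 (within the scatter) and a number 7.6 percentage points lower from compound 1 to compound 3 (within the scatter) both stay within the scatter. For the compounds shown here, a six-membered ring on this nitrogen therefore need not end up beyond the scatter from methyl, as compound 3 shows, although the cyclohexyl of compound 2 does, so a number 17.6 percentage points lower from compound 1 to compound 2 (beyond the scatter) remains the only clear step at this position. Nothing measured on these compounds bears on why the two six-membered rings differ from methyl to different degrees.

Open, as far as these compounds go, is whether unsubstituted phenyl or benzyl on this nitrogen would read like 4-methylphenyl. Also open, from the compounds shown here alone, is how the unsubstituted amine or an ethyl or isopropyl group would fall relative to methyl.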